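Replacing 3-hydroxyphenyl with 4-chlorophenyl on compound 2

This account rests on a few compounds, and the source may have more. Where it says the series, first, only, none or still open, it means among the compounds named here.

In a functional assay on CCRF-CEM cells (Homo sapiens) for inhibition, read by MTT assay, with a stated time of 72 h (a higher number here means a weaker inhibitor, a lower number a stronger inhibitor), compound 1 (`COc1cc(NC(C)CCCNC(=O)NNC(=O)Nc2ccc(F)cc2)c2ncccc2c1`) gives 118000 nM, while compound 2 (`COc1cc(NC(C)CCCNC(=O)Nc2cccc(O)c2)c2ncccc2c1`) gives 32000 nM, the lower of the two numbers measured. Compound 3 (`COc1cc(NC(C)CCCNC(=O)Nc2ccc(Cl)cc2)c2ncccc2c1`) carries 4-chlorophenyl in place of 3-hydroxyphenyl on an amide-type nitrogen. Among the measured compounds shown here, the only measured step, a 3.7-fold lower number from compound 1 to compound 2 (0.57 log units; beyond the scatter), is modest and exchanges a different group, so it offers only a loose guide to size. No change beyond the scatter is therefore expected, and the estimated step is a 1.5-fold lower number from compound 2 to compound 3 (0.16 log units; within the scatter). The expected value for compound 3 in this assay is 22000 nM, within a range of 7000 nM to 70000 nM.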

Compound 3, half-maximal inhibitory concentration: 24000 nM
Compound 3: the middle estimate sits 1.1-fold (0.04 log units) below what was measured; the measured number falls inside the stated range.
By their numbers in this assay, from the lowest: compounds 3 and 2 (each within the scatter of the next); then compound 1.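

In this assay, 4-chlorophenyl on the amide-type nitrogen gives a 1.3-fold lower number from compound 2 to compound 3 (0.12 log units; within the scatter), so this position shows no measurable difference between the two phenyl groups, although the hydrogen-bond donor and acceptor counted on 3-hydroxyphenyl are absent from 4-chlorophenyl. Against the ((4-fluorophenyl)carbamoyl)amino group, the change gives a 4.9-fold lower number from compound 1 to compound 3 (0.69 log units; beyond the scatter), which matches the separation already seen with 3-hydroxyphenyl.
No measurement at hand explains these numbers.

As far as these compounds go, whether an amine or a carboxylic acid in place of these phenyl groups would shift the number beyond the scatter remains open, as does the outcome with a longer chain on that nitrogen.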